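Adding an aromatic ring to a weak growth inhibitor

This account rests on a few compounds, and the source may have more. Where it says the series, first, only, none or still open, it means among the compounds named here.

compound 1 `CC1=CC[C@@H]([C@@](C)(O)CCCC(C)(C)NC(=S)NN)CC1`: 12800 nM
compound 2 `CC1=CC[C@@H]([C@@](C)(O)CCCC(C)(C)NC(=S)N/N=C\c2cccc([N+](=O)[O-])c2)CC1`: 8290 nM

In a functional assay on NCI-H460 cells (Homo sapiens) for cytotoxicity, read by sulforhodamine B assay (on this read-out lower numbers stand for stronger inhibition of growth and higher numbers for weaker inhibition of growth), compound 1 gives 12800 nM and compound 2 gives 8290 nM, so these two values lie within the usual scatter of each other. Compound 3 `CC1=CC[C@@H]([C@@](C)(O)CCCC(C)(C)NC(=S)N/N=C(/C)c2ccccc2)CC1` has not been measured yet. It keeps the core of compound 1, but the amino group on an amide-type nitrogen gives way to a larger group carrying an aromatic ring: a group of 9 heavy atoms (8 carbon, 1 nitrogen; one six-membered aromatic ring of carbon only) in place of one nitrogen atom, on an amide-type nitrogen. Compound 2 also carries a six-membered aromatic ring of carbon only, and its value of 8290 nM stays within the scatter of compound 1 at 12800 nM. No step beyond the scatter is therefore expected in this assay, in either direction. The expected change is a 1.6-fold lower number from compound 1 to compound 3 (0.20 log units; within the scatter). Compound 3 is estimated at 8000 nM, with an expected range from 3000 nM to 18000 nM.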

Compound 3, concentration for 50% growth inhibition: 12600 nM
Beside the measured number, compound 3's estimate is 1.6-fold (0.20 log units) below it; the range from low to high includes it.
By their numbers in this assay, from the lowest: compounds 2, 3 and 1 (each within the scatter of the next).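

In this assay, placing the larger group with its six-membered aromatic ring on the amide-type nitrogen, in place of the amino group, gives a 1.0-fold lower number from compound 1 to compound 3 (0.01 log units; within the scatter). This position therefore takes a group of 9 heavy atoms without a step beyond the scatter, even though the amino group counts as a hydrogen-bond donor and the entering group does not. Nothing available here bears on why the number holds steady.

Still open, as far as these compounds go, is whether any group at this position can move the number beyond the scatter, since this one change gives no sign of which way such a step might go. An amine or a carboxylic acid on the aromatic ring, for instance, could test that.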